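A few compounds are considered here, and "the series" means these few. Any claim that something is new, unique, unknown or untested is made for them only; others in the source may bear on it.

Measured so far:
compound 1 `CC(=O)Nc1cc(-c2ccc(N(C)C(=O)c3c(F)cccc3Cl)c(N3CCCCC3)c2)n(C(C)C)n1` gives 1.3 ug/mL
compound 2 `CC(=O)Nc1cc(-c2cnc(N(C)C(=O)c3c(F)cccc3Cl)c(N3CCCCC3)c2)n(C(C)C)n1` gives 37.4 ug/mL
compound 3 `CC(C)n1nc(C(N)=O)cc1-c1ccc(N(C)C(=O)c2c(F)cccc2Cl)c(OCC(F)(F)F)c1` gives 32 ug/mL

In a physicochemical assay for solubility, measured as kinetic solubility (a lower number here means a less soluble compound, a higher number a more soluble compound), compound 3 stands second highest of the three numbers. Its nearest neighbour is compound 2, and the gap between compound 2 and compound 3 lies within the scatter, so no order between them can be read. Compound 1 lies far lower than compound 3, a gap beyond the scatter. Among the compounds with values here, compound 1 and compound 2 share acetamido and a piperidinyl substituent, while compound 3 carries carbamoyl and trifluoroethoxy; none of the measured pairs differ in a single place, so no clean step is available.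

Compound 4 `CC(=O)Nc1cc(-c2ccc(N(C)C(=O)c3c(F)cccc3Cl)c(OCC(F)(F)F)c2)n(C(C)C)n1` differs from compound 3 in one place: acetamido in place of carbamoyl on an aromatic carbon. The trifluoroethoxy of compound 3 is kept. Within the data shown here, nothing among the measured compounds isolates this change, so the expected step of a 1.6-fold lower number from compound 3 to compound 4 (0.20 log units; within the scatter) is small, either within the scatter or a slight decrease. Compound 4 is expected at 20 ug/mL, with a range from 6 ug/mL to 60 ug/mL.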

Compound 4, solubility: 27 ug/mL
Estimate against measurement, compound 4: 1.4-fold (0.13 log units) below, and the stated range covers the measured number.
By their numbers in this assay, from the lowest: compound 1; then compounds 4, 3 and 2 (each within the scatter of the next).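

Within the data shown here, with the 2,2,2-trifluoroethoxy kept, the first single-place reading on this aromatic carbon of the five-membered ring is a 1.2-fold lower number from compound 3 to compound 4 (0.07 log units; within the scatter) in this assay, so acetamido and carbamoyl cannot be told apart here. With acetamido kept, the exchange of piperidin-1-yl for 2,2,2-trifluoroethoxy gives a 21-fold higher number from compound 1 to compound 4 (1.32 log units; beyond the scatter), a large step that sets this second place apart from the first in this series. Nothing at hand bears on the cause of either step.

Open, going by these compounds, is whether acetamido and carbamoyl also read alike with piperidin-1-yl in the other place, since only one substituent context is covered. Also open, on these data alone, is how a primary amine or a carboxylic acid on the same aromatic carbon would read in this assay.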